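Removing One Hydroxy from Compound 3

The source may hold more compounds than are shown below. What is called first, only, known or untested is meant among the compounds shown, and "the series" means these compounds.

- Compound 1 `COc1ccc(C(=O)/C=C/c2ccc(F)cc2)c(O)c1`: 18400 nM
- Compound 2 `O=C(/C=C/c1ccc(N2CCCC2)cc1)c1ccc(O)cc1`: 620 nM
- Compound 3 `O=C(/C=C/c1ccc(F)cc1)c1ccc(O)cc1O`: 9430 nM

In a functional assay on SNU-638 cells (Homo sapiens) for cytotoxicity, read by MTT assay (a higher number here means a weaker inhibitor, a lower number a stronger inhibitor), compound 3 gives 9430 nM. That number lies within the scatter of compound 1 and well above that of compound 2, so only compound 2 clearly separates from it.

Compound 4 `O=C(/C=C/c1ccc(F)cc1)c1ccc(O)cc1` is compound 3 with a single change: hydrogen in place of hydroxy on an aromatic carbon, ortho to a large group and meta to a hydroxy group (hydrogen in place of hydroxy on an aromatic carbon).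

Among the measured compounds shown here, only one measured step is available as a guide. It is a 2.0-fold lower number from compound 1 to compound 3 (0.29 log units; within the scatter), and it concerns hydrogen in place of methyl on an oxygen, not the hydroxy that leaves here. It shows that one change to this ring left the number within the scatter, but it does not measure the present change directly. Compound 2, at 620 nM, also lacks this hydroxy, but it differs from compound 4 elsewhere too, so it cannot isolate the step.

With so little evidence, no shift beyond the scatter is expected in either direction. The expected step is a 1.1-fold higher number from compound 3 to compound 4 (0.03 log units; within the scatter). For compound 4 the estimated value is 10000 nM, with an expected range of 3500 nM to 30000 nM.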

Compound 4, half-maximal inhibitory concentration: 5540 nM
Beside the measured number, compound 4's estimate is 1.8-fold (0.26 log units) above it; the range from low to high includes it.
By their numbers in this assay, from the lowest: compound 2; then compounds 4, 3 and 1 (each within the scatter of the next, the first and the last beyond it).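

In this assay, taking away this hydroxy and leaving hydrogen on the aromatic carbon gives a 1.7-fold lower number from compound 3 to compound 4 (0.23 log units; within the scatter), so with fluoro on the other aromatic ring, the group can go without a shift that stands clear of the usual variation between repeats. The new compound also provides a comparison with a single change elsewhere in the molecule, fluoro in place of pyrrolidin-1-yl on an aromatic carbon, and that change gives an 8.9-fold higher number from compound 2 to compound 4 (0.95 log units; beyond the scatter), a modest step that lies beyond the scatter. Among the compounds shown here, of the two single changes involving compound 4, then, only the one between fluoro and pyrrolidin-1-yl separates the numbers clearly, and nothing available gives a reason for the size of either step.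

Still open, from the compounds shown here alone, is whether the hydroxy step would stay this small in a compound carrying pyrrolidin-1-yl in place of fluoro. Also open, going by these compounds, is how an amine or a chloro group on this same aromatic carbon would compare with hydroxy and hydrogen.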